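This account rests on a few compounds, and the source may have more. Where it says the series, first, only, none or still open, it means among the compounds named here.

Compound 2 `Cc1cc(NC(=O)Cn2nnc(-c3ccc(F)c(F)c3)n2)n(C2CCCCC2)n1` gives 116 nM in an assay on HEK293 cells for activation of Kir3.1/Kir3.2 (Homo sapiens), read by thallium flux (on this read-out higher numbers stand for an effect only at larger amounts of compound and lower numbers for an effect already at smaller amounts), while compound 1 `Cc1cc(NC(=O)Cn2nnc(-c3ccccc3F)n2)n(C2CCCCC2)n1` gives 187 nM in this assay, and the step of a 1.6-fold lower number from compound 1 to compound 2 (0.21 log units; within the scatter) keeps the two within the usual scatter. Compound 3 `Cc1cc(NC(=O)Cn2nnc(-c3cccc(F)n3)n2)n(C2CCCCC2)n1` differs from compound 2 by 6-fluoropyridin-2-yl in place of 3,4-difluorophenyl on an aromatic carbon. Going by the values given here, the only measured step, a 1.6-fold lower number from compound 1 to compound 2 (0.21 log units; within the scatter), exchanged 2-fluorophenyl for 3,4-difluorophenyl; no measured step puts a ring nitrogen into this aromatic ring, so that step bears only loosely here. Compound 3 is therefore expected to land close to its neighbour, the estimated step being a 1.3-fold higher number from compound 2 to compound 3 (0.11 log units; within the scatter). The estimated value for compound 3 is 150 nM, within a range from 60 nM to 400 nM.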

Compound 3, half-maximal effective concentration: > 3000 nM
Compound 3 was reported as a limit (the forecaster's own chance of this, stated with the estimate: 5%); middle value at least 20-fold (1.30 log units) away from the limit.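

Moving from a fluorophenyl group to 6-fluoropyridin-2-yl at this position gives an at least 25-fold higher number from compound 2 to compound 3 (1.41 log units; beyond the scatter) and an at least 16-fold higher number from compound 1 to compound 3 (1.20 log units; beyond the scatter), whereas the exchange between the two fluorophenyl groups stayed within the scatter. So this position can respond sharply when the aromatic ring changes. In this assay compound 3 is reported only as a limit, not as a number: the limit of > 3000 nM in this assay, at which 1 of the 3 values shown sits.

The compounds shown leave open whether the ring nitrogen itself or the placement of the fluorine drives this large step. They also leave open how an unsubstituted pyridin-2-yl, a pyridin-3-yl or a plain phenyl group would read here.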